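Thiophen-2-yl on the sulfonyl sulfur of compound 3

This account rests on a few compounds, and the source may have more. Where it says the series, first, only, none or still open, it means among the compounds named here.

Measured in a functional assay on HL-60 cells (Homo sapiens) for inhibition, read by CCK-8 assay, with a stated time of 48 h, tested at 20 uM; on this read-out lower numbers stand for less inhibition of growth and higher numbers for more inhibition of growth at the one concentration tested:
- compound 1 `Cc1ccc(S(=O)(=O)Oc2cccc(/C=C(\C#N)C(=O)Nc3nnc(C)s3)c2)cc1`: 71%
- compound 2 `COc1ccccc1-c1nnc(NC(=O)/C(C#N)=C/c2cccc(OS(=O)(=O)c3ccc(C)cc3)c2)s1`: 73%
- compound 3 `Cc1ccc(S(=O)(=O)Oc2cccc(/C=C(\C#N)C(=O)Nc3nnc(-c4cccs4)s3)c2)cc1`: 62%

Compound 3 stands close to compound 1 but apart from compound 2. The data show a number 9 percentage points lower from compound 1 to compound 3 (within the scatter), and also a number 11 percentage points lower from compound 2 to compound 3 (beyond the scatter). Compound 4 `N#C/C(=C\c1cccc(OS(=O)(=O)c2cccs2)c1)C(=O)Nc1nnc(-c2cccs2)s1` carries thiophen-2-yl in place of 4-methylphenyl on a sulfonyl sulfur, a change that counts as thiophen-2-yl in place of 4-methylphenyl on a sulfonyl sulfur. Going by the values given here, no measured step touches that place. All three, including a number 2 percentage points higher from compound 1 to compound 2 (within the scatter), change a group on an aromatic carbon, so they bear on this change only indirectly, and they give no direction for it. The two steps that bring in thiophen-2-yl are small, but they do so at that other place. With no evidence for a shift, the expectation starts from compound 3 at 62% in this assay. No change beyond the scatter is expected, and the estimate means a number 2 percentage points lower from compound 3 to compound 4 (within the scatter). The expected value for compound 4 is 60%. The estimated range for compound 4 runs from 45% to 75%.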

Compound 4, percent growth inhibition at one concentration: 30%
Beside the measured number, compound 4's estimate is 30 percentage points above it; measured number below the stated range.
By their numbers in this assay, from the lowest: compound 4; then compounds 3, 1 and 2 (each within the scatter of the next, the first and the last beyond it).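

On a sulfonyl sulfur whose other neighbour is oxygen on an aromatic ring, replacing 4-methylphenyl with thiophen-2-yl gives a number 32 percentage points lower from compound 3 to compound 4 (beyond the scatter) in this assay and shows that this place is far from indifferent to the group it carries. Thiophen-2-yl on an aromatic carbon gave only the smaller steps seen earlier, so the same group can go with very different steps depending on where it enters. No available evidence explains the fall in growth inhibition.

The compounds shown leave open whether the fall follows from the thiophene ring or from the loss of 4-methylphenyl, and a plain phenyl, a pyridine or a simple methyl on the sulfonyl sulfur would help separate these. On these data alone, it is also open whether the same change gives a step of this size with methyl or 2-methoxyphenyl on the aromatic carbon.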